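Swapping phenyl for 1-benzofuran-2-yl in an unreadable series

This account rests on a few compounds, and the source may have more. Where it says the series, first, only, none or still open, it means among the compounds named here.

Of the compounds shown here, three with a shared core have been tested in a functional assay on HCT-116 cells (Homo sapiens), read by MTT assay, with a stated time of 72 h; a lower number here means a stronger inhibitor, a higher number a weaker inhibitor: compound 1 (`COc1nc(N)nc2c1c(-c1ccoc1)cn2[C@@H]1O[C@H](CO)[C@@H](O)[C@H]1O`), compound 2 (`COc1nc(N)nc2c1c(-c1ccsc1)cn2[C@@H]1O[C@H](CO)[C@@H](O)[C@H]1O`) and compound 3 (`COc1nc(N)nc2c1c(-c1ccccc1)cn2[C@@H]1O[C@H](CO)[C@@H](O)[C@H]1O`). Compound 1 gives > 20000 nM, which is a limit and not a number. Compound 2 gives > 20000 nM, again a limit. On these data alone, compound 3 gives > 20000 nM, also a limit, so its exact place among the three is unknown.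

In compound 4 (`COc1nc(N)nc2c1c(-c1cc3ccccc3o1)cn2[C@@H]1O[C@H](CO)[C@@H](O)[C@H]1O`), 1-benzofuran-2-yl replaces phenyl on an aromatic carbon: 1-benzofuran-2-yl in place of phenyl on an aromatic carbon. Three swaps of this aromatic group have been measured: a step that the two limits leave unreadable from compound 1 to compound 2, a step that the two limits leave unreadable from compound 1 to compound 3 and a step that the two limits leave unreadable from compound 2 to compound 3. None of them has a readable size. All three compounds sit at one value, (the limit of > 20000 nM in this assay, at which 3 of the 3 values shown sit). Within the data shown here, with a step that the two limits leave unreadable from compound 1 to compound 3 and a step that the two limits leave unreadable from compound 2 to compound 3 as the closest guides, no step of known size or direction can be expected in this assay. The estimated step is a number no higher from compound 3 to compound 4 (the limit leaves the size open), and a reported limit is the likeliest result. For compound 4 the expected value is 20000 nM, with an estimated range from 8000 nM to 40000 nM.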

Compound 4, half-maximal inhibitory concentration: > 20000 nM
Compound 4: only a limit was reported; the forecaster's own chance of this, stated with the estimate: 80%; the middle value sits exactly at the limit.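

In this assay compound 4 gives > 20000 nM, again a limit and not a number, so no step between it and compound 1, compound 2 or compound 3 can be read: the limit of > 20000 nM in this assay, at which 4 of the 4 values shown sit.

On these data alone, how these four compounds rank against one another, and whether changing this aromatic group alters their strength at all, remains open.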